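Furan in place of triazole on a benzimidazole antagonist series

This account rests on a few compounds, and the source may have more. Where it says the series, first, only, none or still open, it means among the compounds named here.

Measured compounds:
Compound 1 `FC(F)(F)c1ccc2[nH]c(-c3ccc(-c4nnc[nH]4)cc3)nc2c1` — in a functional assay for antagonist activity at Neuropeptides B/W receptor type 1 (Homo sapiens), read by cAMP accumulation (on this read-out lower numbers stand for stronger inhibition and higher numbers for weaker inhibition), compound 1 gives 3080 nM
Compound 2 `Cc1cc(Cl)ccc1-c1nc2cc([N+](=O)[O-])ccc2[nH]1` — in this assay compound 2 gives 2490 nM

Compound 1 has the highest of the two numbers, but its gap to compound 2 lies within the scatter, so the two cannot be ordered. Compound 3 `FC(F)(F)c1ccc2[nH]c(-c3ccc(-c4ccoc4)cc3)nc2c1` differs from compound 1 in one place: furan-3-yl in place of 4H-1,2,4-triazol-3-yl on an aromatic carbon, on an aromatic carbon of a six-membered aromatic ring of carbon only, para to a large group. Among the measured compounds shown here, no measured pair shows this change, so compound 3 is expected to sit near compound 1, with the step of a 1.3-fold higher number from compound 1 to compound 3 (0.11 log units; within the scatter) estimated as small and uncertain in direction. Compound 3 is estimated at 4000 nM, within 1500 nM to 12000 nM.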

Compound 3, half-maximal inhibitory concentration: 1190 nM
Compound 3: middle estimate off by 3.4-fold (0.53 log units), on the high side; the measured number lies below the stated range.
By their numbers in this assay, from the lowest: compound 3; then compounds 2 and 1 (each within the scatter of the next).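

In this assay, furan-3-yl in place of 4H-1,2,4-triazol-3-yl gives a 2.6-fold lower number from compound 1 to compound 3 (0.41 log units; beyond the scatter) on this aromatic carbon, the first sign that the number responds to the five-membered ring placed here. Both groups count 5 heavy atoms, so the step appears with no change in that count. Nothing at hand accounts for the step. As far as these compounds go, whether furan-2-yl, a thiophene or a carboxylic acid in this place would lower the number further remains open. This single pair also cannot say whether the step would hold on another core.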